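The compounds below may be only part of what the source reports. "The series", "measured", "known", "first", "only" and "open" are said of these compounds alone.

Of the compounds shown here, three from one series have been tested in a functional assay on A549 cells (Homo sapiens) for antiproliferative activity, read by MTT assay, with a stated time of 72 h; a higher number here means a weaker inhibitor, a lower number a stronger inhibitor. Compound 1 `CC/C=C\C(=O)Nc1cc(Nc2nc(C)cc(-c3cn(C)c4ccccc34)n2)c(OC)cc1N(C)CCN(C)C` gives 1090 nM in this assay. Compound 2 `CC/C=C\C(=O)Nc1cc(Nc2nccc(-c3cn(C)c4ccc(F)cc34)n2)c(OC)cc1N(C)CCN(C)C` gives 3600 nM in this assay. Compound 3 `C=CC(=O)Nc1cc(Nc2nc(C)cc(-c3cn(C)c4ccc(F)cc34)n2)c(OC)cc1N(C)CCN(C)C` gives 1490 nM in this assay. Among these three numbers, compound 3 stands second highest: its number lies close to that of compound 1, a gap that falls within the usual scatter of repeated measurements, whereas the number of compound 2 is higher by a gap that goes beyond that scatter.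

Compound 4 `CC/C=C\C(=O)Nc1cc(Nc2nc(C)cc(-c3cn(C)c4ccc(F)cc34)n2)c(OC)cc1N(C)CCN(C)C` has not yet been measured. It differs from compound 3 in one place: but-1-en-1-yl in place of vinyl on a carbonyl carbon. For the measured compounds named here, no measured pair in this set shows that same change on its own, so its effect cannot be read off directly. The two compounds that already carry the but-1-en-1-yl group, compound 1 and compound 2, sit on either side of compound 3, one within its scatter and one beyond it, but each of them also differs from compound 3 in other parts of the structure. On that footing, compound 4 is expected to give about 1500 nM in this assay, somewhere between 600 nM and 4000 nM. That estimate means an expected step from compound 3 to compound 4 of a 1.0-fold higher number from compound 3 to compound 4 (0.00 log units; within the scatter), which would stay within the scatter.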

Compound 4, half-maximal inhibitory concentration: 9150 nM
Compound 4: middle estimate off by 6.1-fold (0.79 log units), on the low side; the whole stated range lies below it.
By their numbers in this assay, from the lowest: compounds 1 and 3 (each within the scatter of the next); then compound 2; then compound 4.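

In this assay, putting but-1-en-1-yl in place of vinyl on the carbonyl carbon, with nothing else changed, gives a 6.1-fold higher number from compound 3 to compound 4 (0.79 log units; beyond the scatter) and so a weaker inhibitor, which shows that the group at this position matters and that the longer of these two chains is the worse one on this core. With but-1-en-1-yl in place, two small changes elsewhere also go with weaker inhibition: methyl in place of hydrogen on an aromatic carbon gives a 2.5-fold higher number from compound 2 to compound 4 (0.41 log units; beyond the scatter) and fluoro in place of hydrogen on an aromatic carbon gives an 8.4-fold higher number from compound 1 to compound 4 (0.92 log units; beyond the scatter), so the methyl and the fluoro each count on their own in this background. No measurement at hand explains why any of these numbers rise.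

For the compounds shown here, only one pair isolates the change from vinyl to but-1-en-1-yl, so whether it has a similar effect on a core lacking the fluoro or the methyl remains open. Also open, from the compounds shown here alone, is how other groups on the same carbonyl carbon would behave, such as a saturated propyl chain or a dimethylaminomethyl-bearing vinyl group, which would show whether chain length or the amine matters here.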